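Sulfonamide nitrogen substituent: aryl to pyrimidinyl step

The source may hold more compounds than are shown below. What is called first, only, known or untested is meant among the compounds shown, and "the series" means these compounds.

Compound 3 `O=C(Nc1ccc(S(=O)(=O)Nc2cccc(Cl)c2)cc1)c1ccc(Cl)cc1Cl` gives 575 nM in a functional assay on HEK293 cells for agonist activity at probable G-protein coupled receptor 27 (Homo sapiens), read by a luciferase reporter and beta-arrestin recruitment, with a stated time of 10 min (on this read-out lower numbers stand for an effect already at smaller amounts and higher numbers for an effect only at larger amounts of compound), and holds the lowest of the two numbers shown. Compound 2 `CN(c1ccccc1)S(=O)(=O)c1ccc(NC(=O)c2ccc(Cl)cc2Cl)cc1` gives 2570 nM in this assay. Compound 1 `O=C(NS(=O)(=O)c1ccc(NC(=O)c2ccc(Cl)cc2Cl)cc1)c1ccccc1` reaches only a limit of the assay, > 100000 nM, in this assay. The steps to compound 3 were an at least 170-fold lower number from compound 1 to compound 3 (2.24 log units; beyond the scatter) and a 4.5-fold lower number from compound 2 to compound 3 (0.65 log units; beyond the scatter), and an at least 38-fold lower number from compound 1 to compound 2 (1.59 log units; beyond the scatter); the limit of > 100000 nM in this assay, at which 1 of the 3 values shown sits, means the steps from compound 1 are lower bounds only.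

Compound 4 `O=C(Nc1ccc(S(=O)(=O)Nc2ncccn2)cc1)c1ccc(Cl)cc1Cl` differs from compound 3 by pyrimidin-2-yl in place of 3-chlorophenyl on a sulfonamide nitrogen. No measured step swaps one aromatic ring for another on that nitrogen; the steps shown replace an acyl group or a methyl(phenyl)amino with an aryl amine and are large or modest. They say that an aryl group on the sulfonamide nitrogen suits compound 3, but nothing about pyrimidin-2-yl against 3-chlorophenyl. The expectation is therefore a step of modest size towards a higher number, a 4.3-fold higher number from compound 3 to compound 4 (0.64 log units; beyond the scatter), and compound 4 is expected at 2500 nM with a range of 600 nM to 15000 nM.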

Compound 4, half-maximal effective concentration: > 100000 nM
Compound 4 gave a limit, no number (the forecaster's own chance of this, stated with the estimate: 15%); middle value at least 40-fold (1.60 log units) away from the limit.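

Among the compounds shown here, earlier steps showed only that an aryl group on the sulfonamide nitrogen suits the series better than benzoyl; compound 4 shows that an aromatic ring there is not enough, with pyrimidin-2-yl in place of 3-chlorophenyl giving an at least 170-fold higher number from compound 3 to compound 4 (2.24 log units; beyond the scatter) in this assay. The comparison with the methyl(phenyl)amino form points the same way, with an at least 38-fold higher number from compound 2 to compound 4 (1.59 log units; beyond the scatter). Both steps are lower bounds because compound 4 gives only a limit of the assay, not a number: the limit of > 100000 nM in this assay, at which 2 of the 4 values shown sit.

The step between compound 1 and compound 4 cannot be read, as both are limits. Going by these compounds, whether the change follows the two ring nitrogens or the loss of the chlorine stays open, and an unsubstituted phenyl or a pyridin-2-yl on the sulfonamide nitrogen would separate the two.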